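The source may report more compounds than this note shows. Statements on the series, on what has been measured and on what is new or still open speak of the compounds shown alone.

Of the compounds shown here, three built on a shared core have so far been tested in an ADME assay on a cell-free system (plasma, Homo sapiens), with a stated time of 30 min; on this read-out higher numbers stand for a more stable compound and lower numbers for a less stable compound. Compound 1 (`COc1ccccc1C(=O)N[C@]1(OC)C(=O)N2C(C(=O)OCc3cccc(C)c3)=C(CSc3nnnn3CC(=O)O)CO[C@@H]21`) gives 11%, and compound 2 (`COc1ccccc1C(=O)N[C@]1(OC)C(=O)N2C(C(=O)OC(c3ccccc3)c3ccccc3)=C(CSc3nnnn3C)CO[C@@H]21`) gives 73%. Compound 3 (`CO[C@@]1(NC(=O)c2ccccc2OC(C)C)C(=O)N2C(C(=O)OCc3ccc(C(=O)O)cc3)=C(CSc3nnnn3C)CO[C@@H]21`) gives 42%, the middle of the three numbers, with the gap to each of the other two beyond the usual scatter. Among the measured compounds shown here, these three compounds differ from one another in more than one place, so no measured pair isolates a single structural change.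

Compound 4 (`CO[C@@]1(NC(=O)c2ccccc2Oc2ccccc2)C(=O)N2C(C(=O)OCc3ccc(C(=O)O)cc3)=C(CSc3nnnn3C)CO[C@@H]21`) departs from compound 3 in one place only: phenyl in place of isopropyl on an oxygen on an aromatic ring. This puts phenyl in place of isopropyl on an oxygen on an aromatic ring. For the measured compounds named here, nothing measured so far shows what this swap does, so the expectation is anchored on compound 3 at 42%, and no step beyond the scatter is expected in this assay. The expected change is small and downward, a number 4 percentage points lower from compound 3 to compound 4 (within the scatter). For compound 4 the estimated value is 38%, with an expected range of 18% to 60%.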

Compound 4, percent of the compound remaining: 63%
Compound 4: the middle estimate sits 25 percentage points below what was measured, and the stated range ends below it.
By their numbers in this assay, from the lowest: compound 1; then compound 3; then compounds 4 and 2 (each within the scatter of the next).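

Among the compounds shown here, this is the first change in one place only, and it shows that the group on an oxygen on an aromatic ring counts in this assay: phenyl in place of isopropyl gives a number 21 percentage points higher from compound 3 to compound 4 (beyond the scatter). The rest of the structure stays the same across this pair, so isopropoxy to phenoxy is enough on its own to move the read-out beyond the usual scatter. No supporting measurement is available to explain why this swap gives a more stable compound.

One pair cannot separate the effect of the aromatic ring from that of the larger group, since phenyl brings both. As far as these compounds go, it remains open how a cyclohexyl or a methyl group on the same oxygen would read, and whether the swap would act the same way with a different ester on the shared core.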